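The source may report more compounds than this note shows. Statements on the series, on what has been measured and on what is new or still open speak of the compounds shown alone.

The study compares three measured compounds and one that awaits measurement. Compound 1 `CCCCCCC1C(=O)N(O)C(=O)c2ccccc21` carries a pentyl chain on its saturated core; compound 3 `O=C1c2ccccc2C(Cc2ccccc2)C(=O)N1O` carries a phenyl group at the corresponding position; compound 2 `O=c1c2ccccc2c(Cc2ccccc2)c(O)n1O` holds the same atoms as compound 3, but joined differently, and how the two cores differ is not broken down here.

In an ADME assay on MT4 cells (Homo sapiens) for cytotoxicity, read by MTT assay (a higher number here means that more compound is tolerated, a lower number that less compound is tolerated), compound 1 gives 4400 nM. In this assay compound 3 gives 95000 nM, and compound 2 gives 88000 nM. The values of compound 2 and compound 3 lie within the scatter of each other, so nothing separates them. Within the data shown here, the one counted step runs a 22-fold lower number from compound 3 to compound 1 (1.33 log units; beyond the scatter); its change is pentyl in place of phenyl on a saturated chain carbon bound to a saturated ring carbon.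

Compound 4 `CCCCCCc1c(O)n(O)c(=O)c2ccccc12` is built from compound 2 by pentyl in place of phenyl on a saturated chain carbon bound to an aromatic carbon. This is the same kind of change as from compound 3 to compound 1, but the place differs: in compound 4 the chain carbon is bound to an aromatic carbon, while in compound 1 it is bound to a saturated ring carbon. Because the step of a 22-fold lower number from compound 3 to compound 1 (1.33 log units; beyond the scatter) was large, a step of similar direction is expected, a 15-fold lower number from compound 2 to compound 4 (1.17 log units; beyond the scatter), though the different surroundings of the place leave room for a smaller shift. Compound 4 is therefore expected to give 6000 nM, most likely between 2000 nM and 20000 nM.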

Compound 4, half-maximal cytotoxic concentration: 128000 nM
Estimate against measurement, compound 4: 21-fold (1.33 log units) below; the whole stated range lies below it.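

In this assay, pentyl in place of phenyl on a saturated chain carbon bound to an aromatic carbon gives a 1.5-fold higher number from compound 2 to compound 4 (0.16 log units; within the scatter), so on this core the change stays within the scatter and the large step seen on the other core does not carry over. The same change therefore cannot be treated as one transferable step between these two cores in this assay: the same change on two cores in this assay, a 22-fold lower number (1.33 log units; beyond the scatter) from compound 3 to compound 1 and a 1.5-fold higher number (0.16 log units; within the scatter) from compound 2 to compound 4, 31-fold (1.50 log units) apart, beyond the scatter of two such steps. Among these compounds, this shows that, for these compounds, the result of the change depends on the core that carries it, but with only one pair on each core it does not show which difference between the cores matters, or whether any other change would behave in the same way.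

The compounds shown leave open whether a longer chain, or a shorter one such as propyl, would follow the large step on the saturated core and the flat result on the other core. They also leave open whether a group of a different kind in the same place, such as an amine or a carboxylic acid, would separate the two cores as pentyl does.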